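The compounds below may be only part of what the source reports. "The series", "measured", "known", "first", "only" and "open" are said of these compounds alone.

Measured compounds:
- compound 1, `COc1cc(Cl)cc(-c2nn(-c3cccc(NC(=O)Nc4ccc(Cl)c(C(F)(F)F)c4)c3)cc2-c2ccncc2)c1`: 98%
- compound 2, `COc1cc(Cl)cc(-c2nn(-c3cccc(NC(=O)Nc4cc(C(F)(F)F)cc(C(F)(F)F)c4)c3)cc2-c2ccncc2)c1`: 98%
- compound 3, `COc1cc(Cl)cc(-c2nn(-c3cccc(NC(=O)Nc4ccc(Cl)c(Cl)c4)c3)cc2-c2ccncc2)c1`: 100%

In a functional assay on SW-620 cells (Homo sapiens) for inhibition, read by sulforhodamine B assay, with a stated time of 48 h, tested at 0.01 uM (a higher number here means a weaker effect of the compound at the concentration tested, a lower number a stronger effect), compound 1 gives 98%. Compound 1 stands level with compound 2 at the digits printed, and together they are the lowest of the three numbers; compound 3 lies a number 2 percentage points higher from compound 1 to compound 3 (within the scatter), a step within the scatter. All three compounds therefore sit at the same high level, which at the concentration tested means only a weak effect for each.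

Compound 4, `COc1cc(Cl)cc(-c2nn(-c3cccc(NC(=O)Nc4cccc(C(F)(F)F)c4)c3)cc2-c2ccncc2)c1`, has not yet been measured. It differs from compound 1 in one place: hydrogen in place of chloro on an aromatic carbon. For the measured compounds named here, the only measured step that bears on this part of the molecule is the one from compound 1 to compound 3, where a chloro replaced a trifluoromethyl on the same ring and moved the number only within the scatter. Going by the values given here, no measured pair covers the removal of the chloro itself, so that gap is simply unknown here.

Given that every change on this ring so far left the number within the scatter, compound 4 is expected to show no shift beyond the scatter, no change at the digits printed from compound 1 to compound 4 (within the scatter). The estimate for compound 4 is 98%, with a range from 90% to 105%.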

Compound 4, a percentage reported as activity, at one concentration (the size of the read-out at that concentration, not a potency): 103%
Compound 4: the middle estimate sits 5 percentage points below what was measured; low and high end bracket the measured number.
By their numbers in this assay, from the lowest: compounds 1, 2, 3 and 4 (each within the scatter of the next).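

In this assay, taking the chloro off the 4-chloro-3-(trifluoromethyl)phenyl group gives a number 5 percentage points higher from compound 1 to compound 4 (within the scatter), so this position, para to a large group and ortho to a trifluoromethyl group, carries hydrogen as well as chloro with no step beyond the scatter. The other two steps to compound 4 read the same way, with a number 3 percentage points higher from compound 3 to compound 4 (within the scatter) for 3-(trifluoromethyl)phenyl in place of 3,4-dichlorophenyl and a number 5 percentage points higher from compound 2 to compound 4 (within the scatter) for hydrogen in place of trifluoromethyl, so the 3-(trifluoromethyl)phenyl group cannot be told apart from any of the three more heavily substituted groups at the concentration tested. No measurement shown here offers an explanation for this flat picture.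

The compounds shown leave open whether an amine or a carboxylic acid at this same position, in place of the chloro, would move the number beyond the scatter. They also leave open whether these four compounds would separate at a higher concentration, since a single concentration at which all of them sit at this high level says nothing about their potency.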